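The source may report more compounds than this note shows. Statements on the series, on what has been measured and on what is new or still open speak of the compounds shown alone.

Series notes. Compound 1 `CCN(CC)CCNC(=O)c1ccc(C(CC)(CC)c2ccc(OCC(=O)C(C)(C)C)c(C)c2)n1CC` in an assay on HL-60 cells for agonist activity at vitamin D3 receptor (Homo sapiens), read by microscopy, with a stated time of 96 h (on this read-out higher numbers stand for an effect only at larger amounts of compound and lower numbers for an effect already at smaller amounts), gives 91 nM. Compound 2 `CCn1c(C(=O)NCCN(C)C)ccc1C(CC)(CC)c1ccc(OCC(=O)C(C)(C)C)c(C)c1` gives 77 nM in this assay, and compound 3 `CCn1c(C(=O)NCCN(C)C)ccc1C(CC)(CC)c1ccc(OCC(O)C(C)(C)C)c(C)c1` gives 14 nM. The step of a 1.2-fold lower number from compound 1 to compound 2 (0.07 log units; within the scatter) alters the amine on a saturated chain carbon two bonds along the chain from the amide-type nitrogen; the step of a 5.5-fold lower number from compound 2 to compound 3 (0.74 log units; beyond the scatter) alters the group on the saturated chain carbon bound to the oxygen on the aromatic ring. On the three numbers compound 3 stands lowest, with compound 2 the nearest and compound 1 the furthest from it, both beyond the scatter.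

Compound 4 `CCn1c(C(=O)N(C)c2ccccc2)ccc1C(CC)(CC)c1ccc(OCC(O)C(C)(C)C)c(C)c1` is not yet measured. Relative to compound 3 the change is methyl(phenyl)amino in place of (2-(dimethylamino)ethyl)amino on a carbonyl carbon. Of the measured steps only a 1.2-fold lower number from compound 1 to compound 2 (0.07 log units; within the scatter) touches the same part of the molecule, and it was within the scatter; it exchanged the substituents on the amine but kept the amine and the amide hydrogen, whereas here both are lost, so it gives little guidance on size. The step of a 5.5-fold lower number from compound 2 to compound 3 (0.74 log units; beyond the scatter) lies at the other end of the shared core and does not bear on this change. For compound 4 a modest rise in the number is expected, a 2.1-fold higher number from compound 3 to compound 4 (0.33 log units; beyond the scatter), with wide uncertainty. Compound 4 is therefore estimated at 30 nM, within a range from 8 nM to 120 nM.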

Compound 4, half-maximal effective concentration: 6400 nM
For compound 4 the middle estimate is 210-fold (2.33 log units) below the measured one, and the stated range ends below it.
By their numbers in this assay, from the lowest: compound 3; then compounds 2 and 1 (each within the scatter of the next); then compound 4.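

On the carbonyl carbon, the exchange of (2-(dimethylamino)ethyl)amino for methyl(phenyl)amino gives a 460-fold higher number from compound 3 to compound 4 (2.66 log units; beyond the scatter) in this assay, so this position is far less tolerant than a 1.2-fold lower number from compound 1 to compound 2 (0.07 log units; within the scatter) suggested when only the substituents on the amine changed. Compound 4 keeps the 1-hydroxy-2,2-dimethylpropyl group of compound 3, which accounted for a 5.5-fold lower number from compound 2 to compound 3 (0.74 log units; beyond the scatter), so that group alone does not secure a low number in this series. Nothing at hand gives an explanation for the size of the new step.

The change removes the amine and the amide hydrogen and brings in a methyl group and a phenyl ring all at once, and the compounds shown do not separate these contributions. Still open, going by these compounds, is whether a (2-(dimethylamino)ethyl)(methyl)amino group, which keeps the amine but loses the amide hydrogen, or a phenylamino group, which keeps the amide hydrogen but loses the amine, would stay closer to compound 3, and whether a morpholine or a carboxylic acid at the end of the chain could replace the dimethylamino group.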